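This account rests on a few compounds, and the source may have more. Where it says the series, first, only, none or still open, it means among the compounds named here.

Compound 2 `O=C(O)c1csc([C@H]2CC[C@@H]3[C@@H](COc4cccc(Cl)c4)[C@H](O)C[C@@H]3O2)n1` is the chloro member of the set. In an assay on HEK293 cells for agonist activity at prostaglandin E2 receptor EP2 subtype (Homo sapiens), read by a beta-galactosidase reporter and beta-arrestin recruitment, with a stated time of 90 min (on this read-out lower numbers stand for an effect already at smaller amounts and higher numbers for an effect only at larger amounts of compound), compound 2 gives only a limit, > 10000 nM, and thus sits at the limit of > 10000 nM in this assay, at which 1 of the 3 values shown sits; on the numbers shown it is the single entry reported as a limit rather than as a number. Compound 3 `O=C(O)c1csc([C@H]2CC[C@@H]3[C@@H](COc4cccc(OC(F)(F)F)c4)[C@H](O)C[C@@H]3O2)n1` carries trifluoromethoxy instead, and in this assay compound 3 gives 69 nM. For the measured compounds named here, the one counted step is an at least 140-fold lower number from compound 2 to compound 3 (2.16 log units; beyond the scatter). Going by the values given here, compound 1 `O=C(O)c1csc([C@H]2CC[C@@H]3[C@@H](COc4ccc(OC(F)(F)F)cc4)[C@H](O)C[C@@H]3O2)n1` differs from compound 3 only in where the trifluoromethoxy sits on the ring, and in this assay compound 1 gives 4500 nM; no step is counted for that pair.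

Compound 4 `O=C(O)c1csc([C@H]2CC[C@@H]3[C@@H](COc4ccccc4Cl)[C@H](O)C[C@@H]3O2)n1` is not yet measured. Its change from compound 2 is 2-chlorophenyl in place of 3-chlorophenyl on an oxygen on a saturated carbon. Among the compounds with values here, no measured step covers a move of the chloro around the ring; the step from compound 2 to compound 3 swaps the group rather than its position, so it does not carry over. With compound 2 at the limit, compound 4 is expected to remain near the limit, an estimated a number no higher from compound 2 to compound 4 (the limit leaves the size open), no step beyond the scatter. The estimate for compound 4 in this assay is 10000 nM, between 1500 nM and 40000 nM.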

Compound 4, half-maximal effective concentration: 203 nM
Compound 4: middle estimate off by 49-fold (1.69 log units), on the high side; measured number below the stated range.
By their numbers in this assay, from the lowest: compound 3; then compound 4; then compound 1. At a limit, above all of these: compound 2.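

Position alone carries a large change in the chloro pair: in this assay, 2-chlorophenyl in place of 3-chlorophenyl on the oxygen gives an at least 49-fold lower number from compound 2 to compound 4 (1.69 log units; beyond the scatter). For the compounds shown here, earlier, the only counted step was a change of group, and the effect of position could be seen only in the printed values for the trifluoromethoxy pair, with compound 1 at 4500 nM and compound 3 at 69 nM. The size of the new step remains a bound, because the value for compound 2 is a limit and not a number: the limit of > 10000 nM in this assay, at which 1 of the 4 values shown sits.

From the compounds shown here alone, it remains open what trifluoromethoxy does at the place the chloro holds in compound 4, and whether position matters as much for other groups on the aromatic ring, such as methyl, nitrile or an amine. The compounds shown also leave open whether this effect of position persists when the oxygen joining the ring to the saturated carbon is replaced by sulfur, or when the chain carrying the ring is longer.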